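A few compounds are considered here, and "the series" means these few. Any claim that something is new, unique, unknown or untested is made for them only; others in the source may bear on it.

Of the compounds shown here, two built on one shared core have been tested in an assay on CHO cells for displacement of a labelled ligand from adenosine receptor A1 (Homo sapiens), tested at 10 uM; a lower number here means less inhibition, a higher number more inhibition at the concentration tested (going by the name of the read-out). Compound 1 `COc1ccc(C(=O)Nc2nn(-c3ccccc3)c(=O)c3ccccc23)cc1` gives 0% in this assay. Compound 2 `COc1ccc(NC(=O)Nc2nn(-c3ccccc3)c(=O)c3ccccc23)c(OC)c1` gives 29%, the higher of the two numbers, and its gap to compound 1 lies beyond the usual scatter. Compound 3 `O=C(Nc1ccccc1)Nc1nn(-c2ccccc2)c(=O)c2ccccc12` differs from compound 2 in one place: phenyl in place of 2,4-dimethoxyphenyl on an amide-type nitrogen. For the measured compounds named here, no step of this kind has been measured here, so the size of the change is uncertain, yet a modest drop is expected, with a number 14 percentage points lower from compound 2 to compound 3 (beyond the scatter) pointing downward in this assay. Compound 3 is therefore estimated at 15%, within 0% to 35%.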

Compound 3, a percentage reported as inhibition, at one concentration (the size of the read-out at that concentration, not a potency): 44%
Estimate against measurement, compound 3: 29 percentage points below, and the stated range ends below it.
By their numbers in this assay, from the lowest: compound 1; then compound 2; then compound 3.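

In this assay, phenyl in place of 2,4-dimethoxyphenyl on the amide-type nitrogen gives a change in the upward direction, a number 15 percentage points higher from compound 2 to compound 3 (beyond the scatter), so neither methoxy group is needed for inhibition at this position. Anilino in place of 4-methoxyphenyl on the carbonyl carbon gives a number 44 percentage points higher from compound 1 to compound 3 (beyond the scatter), the larger of the two steps. No measurement here explains either step.

Which of the two methoxy groups accounts for the first step stays open. So does the effect of a chloro group or an amine on this phenyl ring.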